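This account rests on a few compounds, and the source may have more. Where it says the series, first, only, none or still open, it means among the compounds named here.

In a functional assay on HL-60 cells (Homo sapiens) for cytotoxicity, read by WST assay, with a stated time of 48 h (on this read-out higher numbers stand for weaker inhibition and lower numbers for stronger inhibition), compound 2 `C=CC[C@H]1C[C@@H]([C@@H](O)c2ccccc2)CO[C@@H]1c1ccccc1`, which carries vinyl, gives 36000 nM. Compound 1 `Oc1ccccc1/C=C/C[C@H]1C[C@@H]([C@@H](O)c2ccccc2)CO[C@@H]1c1ccccc1` gives 10800 nM and compound 3 `O[C@@H](c1ccccc1)[C@H]1CO[C@H](c2ccccc2)[C@@H](C/C=C/C2CCCCC2)C1` gives 6260 nM. These two values lie within the scatter of each other, and both are lower than that of compound 2.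

Compound 4 `O[C@@H](c1ccccc1)[C@H]1CO[C@H](c2ccccc2)[C@@H](C/C=C/c2ccncc2)C1` differs from compound 3 by pyridin-4-yl in place of cyclohexyl on a double-bonded chain carbon bound to a double-bonded chain carbon, with pyridin-4-yl in place of cyclohexyl on a double-bonded chain carbon bound to a double-bonded chain carbon. Among the measured compounds shown here, the closest precedent is a 1.7-fold lower number from compound 1 to compound 3 (0.24 log units; within the scatter), an exchange of 2-hydroxyphenyl for cyclohexyl at that same place, which stayed within the scatter. The larger steps, a 3.3-fold higher number from compound 1 to compound 2 (0.52 log units; beyond the scatter) and a 5.8-fold lower number from compound 2 to compound 3 (0.76 log units; beyond the scatter), both involve the vinyl group of compound 2, which plays no part in this change.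

For the measured compounds named here, only one exchange of this kind has been measured, so the precedent is thin, and no step beyond the scatter is expected in this assay. The expected change is a 1.4-fold higher number from compound 3 to compound 4 (0.16 log units; within the scatter). For compound 4 the estimated value is 9000 nM, with an expected range from 3500 nM to 25000 nM.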

Compound 4, half-maximal inhibitory concentration: > 100000 nM
Compound 4: a limit, no number (the forecaster's own chance of this, stated with the estimate: 7%); middle value at least 11-fold (1.04 log units) away from the limit.
By their numbers in this assay, from the lowest: compounds 3 and 1 (each within the scatter of the next); then compound 2. At a limit, above all of these: compound 4.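

Compound 4 gives only a limit, not a number, in this assay: the limit of > 100000 nM in this assay, at which 1 of the 4 values shown sits. The place on a double-bonded chain carbon had so far shown no step beyond the scatter for an exchange of its ring, but pyridin-4-yl changes that, with an at least 15-fold higher number from compound 3 to compound 4 (1.20 log units; beyond the scatter) against cyclohexyl and an at least 9.2-fold higher number from compound 1 to compound 4 (0.96 log units; beyond the scatter) against 2-hydroxyphenyl. The comparison with vinyl also reverses direction: 2-cyclohexylethenyl and 2-(2-hydroxyphenyl)ethenyl both give lower numbers than vinyl, whereas 2-(pyridin-4-yl)ethenyl gives an at least 2.7-fold higher number from compound 2 to compound 4 (0.44 log units; beyond the scatter).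

From the compounds shown here alone, the true size of these steps stays open, for the limit sets only their lower bound. The compounds shown also leave open whether an unsubstituted phenyl or a pyridin-3-yl group at this place would behave like cyclohexyl or like pyridin-4-yl.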